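Replacing the side chain of compound 3 with hydroxy

The source may report more compounds than this note shows. Statements on the series, on what has been measured and on what is new or still open speak of the compounds shown alone.

In a functional assay on B16-F10 cells (Mus musculus) for antiproliferative activity, read by CCK-8 assay, with a stated time of 48 h (a higher number here means a weaker inhibitor, a lower number a stronger inhibitor), compound 3 `COc1ccc(/C=C\c2cc(OC)c(OC)c(OC)c2)cc1OCc1ccc(CN2CC[C@H](C(=O)O)C2)cc1` gives 7000 nM. Compound 2 `COc1ccc(/C=C\c2cc(OC)c(OC)c(OC)c2)cc1OCc1ccc(CNCCO)cc1` gives 6600 nM. These two values lie within the scatter of each other, with a 1.1-fold higher number from compound 2 to compound 3 (0.03 log units; within the scatter). Compound 1 `COc1ccc(/C=C\c2cc(OC)c(OC)c(OC)c2)cc1OCc1ccc(CN[C@H](C(=O)O)[C@H](C)O)cc1` gives > 10000 nM, which is a limit and not a number.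

Compound 4 `COc1ccc(/C=C\c2cc(OC)c(OC)c(OC)c2)cc1OCc1ccc(CO)cc1` carries hydroxy in place of 3-carboxypyrrolidin-1-yl on a saturated chain carbon bound to an aromatic carbon. The measured steps, an at least 1.5-fold lower number from compound 1 to compound 2 (0.18 log units; that floor lies within the scatter) and an at least 1.4-fold lower number from compound 1 to compound 3 (0.15 log units; that floor lies within the scatter), have floors within the scatter, and none of them puts hydroxy on that saturated chain carbon, so they are only a weak guide. The direction rests on compound 2, where a smaller side chain gives an at least 1.5-fold lower number from compound 1 to compound 2 (0.18 log units; that floor lies within the scatter). The expected change is estimated as a 3.5-fold lower number from compound 3 to compound 4 (0.54 log units; beyond the scatter), with wide uncertainty. For compound 4 the estimated value is 2000 nM, within an expected range of 200 nM to 10000 nM.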

Compound 4, half-maximal inhibitory concentration: 6600 nM
The estimate for compound 4 lay 3.3-fold (0.52 log units) below the measured number, within the range that was stated.
By their numbers in this assay, from the lowest: compounds 2, 4 and 3 (each within the scatter of the next). At a limit, above all of these: compound 1.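

In this assay, hydroxy on the saturated chain carbon bound to an aromatic carbon reads level with both amine side chains, with a 1.1-fold lower number from compound 3 to compound 4 (0.03 log units; within the scatter) and no change at the digits printed from compound 2 to compound 4 (within the scatter). Across compound 2, compound 3 and compound 4, neither the side-chain nitrogen nor the carboxylic acid is needed to hold this level. The remaining step, an at least 1.5-fold lower number from compound 1 to compound 4 (0.18 log units; that floor lies within the scatter), rests on compound 1, which is a limit and gives only a floor: the limit of > 10000 nM in this assay, at which 1 of the 4 values shown sits.

From the compounds shown here alone, whether a primary amine, a methyl ether or a longer chain at this place would shift the number stays open. So does whether any change here can move it beyond the scatter.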